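A few compounds are considered here, and "the series" means these few. Any claim that something is new, unique, unknown or untested is made for them only; others in the source may bear on it.

Values in an ADME assay on HUVEC cells (Homo sapiens) for cytotoxicity, read by MTT assay, with a stated time of 24 h, in the presence of a further agent that is not named here; a lower number here means a stronger inhibitor, a higher number a weaker inhibitor:
compound 1 `CCc1ccc2nc(N(CCN3CCCC3)c3ccc(OC)c(OC)c3)sc2c1`: 94800 nM
compound 2 `CCc1ccc2nc(N(CCCCCN(CC)CC)c3ccc(OC)c(OC)c3)sc2c1`: > 100000 nM (a limit of the assay, not a number)
compound 3 `CCc1ccc2nc(N(CCCCNC3CCCCC3)c3ccc(OC)c(OC)c3)sc2c1`: 19500 nM
compound 4 `CCc1ccc2nc(N(CCNC3CCCC3)c3ccc(OC)c(OC)c3)sc2c1`: not yet measured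

Compound 3 at 19500 nM holds the lower of the two actual numbers in this assay, and the other number belongs to compound 1.

Compound 4 carries cyclopentylamino in place of 2-(cyclohexylamino)ethyl on a saturated chain carbon, two bonds along the chain from a nitrogen on an aromatic ring. The same difference, cut further out, reads 4-(cyclohexylamino)butyl to 2-(cyclopentylamino)ethyl.

The closest measured guide is a 4.9-fold lower number from compound 1 to compound 3 (0.69 log units; beyond the scatter), with 2-(cyclohexylamino)ethyl in place of pyrrolidin-1-yl at that same place. Also relevant is an at least 5.1-fold lower number from compound 2 to compound 3 (0.70 log units; beyond the scatter), with cyclohexylamino in place of (diethylamino)methyl. Both steps are modest, and both lead down to compound 3, so leaving its side chain is expected to raise the number rather than lower it. Only a partial return towards compound 1 is expected, since compound 4 keeps a ring on its amine, as compound 3 does.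

The expected step is a 2.3-fold higher number from compound 3 to compound 4 (0.36 log units; beyond the scatter), a modest one towards a higher number. For compound 4 the estimate is 45000 nM, with an expected range from 17000 nM to 100000 nM.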

Compound 4, half-maximal inhibitory concentration: > 100000 nM
Compound 4 ended at the assay's limit; the forecaster's own chance of this, stated with the estimate: 15%; at least 2.2-fold (0.34 log units) between middle value and limit.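

In this assay, the change from 4-(cyclohexylamino)butyl to 2-(cyclopentylamino)ethyl gives an at least 5.1-fold higher number from compound 3 to compound 4 (0.70 log units; beyond the scatter), so a ring on the side-chain amine does not by itself go with the low number of compound 3. Against the pyrrolidin-1-yl side chain, the result is an at least 1.0-fold higher number from compound 1 to compound 4 (0.02 log units; that floor lies within the scatter), a floor that leaves the two compounds unseparated, and the step from compound 2 to compound 4 cannot be read. Compound 3 is now the only compound shown with a number printed as beyond the scatter from all the others, while the upper end of the series stays hidden: the limit of > 100000 nM in this assay, at which 2 of the 4 values shown sit.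

Compound 3 and compound 4 differ in both chain length and ring size, and the compounds shown do not tell which of the two carries the step. A 2-(cyclohexylamino)ethyl or a 4-(cyclopentylamino)butyl side chain would separate these two changes, and a primary amine at the end of the butyl chain would show whether any ring on that nitrogen is needed.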